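Methyl on the ring amine: compound 2 to compound 3

A few compounds are considered here, and "the series" means these few. Any claim that something is new, unique, unknown or untested is made for them only; others in the source may bear on it.

Among the measured compounds shown here, compound 1 `CN1CCCC1COc1cnc(Cl)c(/C=C/c2ccncc2)c1` and compound 2 `Clc1ncc(OCC2CCCN2)cc1/C=C/c1cccnc1` share a core and differ at two places, so no single step links them. In an assay for binding affinity to Neuronal acetylcholine receptor; alpha4/beta2 (Rattus norvegicus) (on this read-out lower numbers stand for stronger inhibition and higher numbers for weaker inhibition), compound 1 gives 0.028 nM. In this assay compound 2 gives 0.028 nM, level with compound 1 at the digits shown and within the scatter; the two values show no difference. Compound 3 `CN1CCCC1COc1cnc(Cl)c(/C=C/c2cccnc2)c1` has not yet been measured in this assay. It differs from compound 2 by one change: methyl in place of hydrogen on an amine nitrogen in a ring. For the measured compounds named here, no measured pair isolates this change, so its size cannot be read from measured steps. Compound 1 carries the same methyl on its ring amine and gives 0.028 nM, which gives no sign that the methyl moves the number either way. The step is therefore expected to be none beyond the scatter, estimated as no change at the digits printed from compound 2 to compound 3 (within the scatter). For compound 3 the expected value in this assay is 0.028 nM, within the range 0.01 nM to 0.08 nM.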

Compound 3, inhibition constant: 0.088 nM
Compound 3: the middle estimate sits 3.1-fold (0.50 log units) below what was measured; measured number above the stated range.
By their numbers in this assay, from the lowest: compounds 1 and 2 (each within the scatter of the next); then compound 3.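

In this assay, the methyl on the amine nitrogen of the five-membered ring now has a measured size: a 3.1-fold higher number from compound 2 to compound 3 (0.50 log units; beyond the scatter), beyond the scatter. The other place also has a measured size, as pyridin-3-yl in place of pyridin-4-yl gives a 3.1-fold higher number from compound 1 to compound 3 (0.50 log units; beyond the scatter), likewise beyond the scatter, so each of the two changes shifts the number when the other place is held fixed. Nothing measured here bears on why either step occurs.

Going by these compounds, whether the methyl step keeps its size with pyridin-4-yl in place of pyridin-3-yl remains open. Also open, on these data alone, is how the number responds to an ethyl group, a longer chain or an acetyl group on that ring nitrogen.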